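Anilino and aryloxy acetamides on a lactone core

The source may hold more compounds than are shown below. What is called first, only, known or untested is meant among the compounds shown, and "the series" means these compounds.

Measured so far:
compound 1, `O=C(COc1ccc(C(=O)/C=C/c2cccc(Br)c2)cc1)N[C@H]1CCOC1=O` — 7890 nM
compound 2, `O=C(CNc1ccccc1)N[C@H]1CCOC1=O` — > 64000 nM
compound 3, `Cc1cc(Cl)ccc1NCC(=O)N[C@H]1CCOC1=O` — > 64000 nM

In a functional assay on PC-3 cells (Homo sapiens) for antiproliferative activity, read by MTT assay, with a stated time of 72 h (a lower number here means a stronger inhibitor, a higher number a weaker inhibitor), compound 1 gives 7890 nM. For compound 2 the value > 64000 nM is a limit of this assay and not a number. For compound 3 the value > 64000 nM is likewise a limit of this assay and not a number. Compound 3 therefore stands at the edge of what this assay can report, and among the three compounds only compound 1 returns a measured number.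

Compound 4, `O=C(CNc1ccc(Cl)cc1)N[C@H]1CCOC1=O`, is not yet measured. It differs from compound 3 in one place: hydrogen in place of methyl on an aromatic carbon. For the measured compounds named here, no step between measured compounds is available for this change; the nearest comparison is compound 2, which also carries an anilino group and sits at the limit. Because the limit of > 64000 nM in this assay, at which 2 of the 3 values shown sit, holds for two of the three values, the expected step from compound 3 to compound 4 is a step that the limit leaves unreadable from compound 3 to compound 4, that is none beyond the scatter. For compound 4 the expected value in this assay is 80000 nM, with a range from 30000 nM to 250000 nM, and the most likely outcome is that this assay again reports only a limit.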

Compound 4, half-maximal inhibitory concentration: > 64000 nM
Compound 4 was reported as a limit (the forecaster's own chance of this, stated with the estimate: 80%); the middle value is on the limit's open side.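

In this assay compound 4 gives > 64000 nM, a limit and not a number. The steps joining compound 4 to compound 2 and compound 3 cannot be read, because each pair ends at the same limit: the limit of > 64000 nM in this assay, at which 3 of the 4 values shown sit.

The compounds shown leave open whether the chloro or methyl group changes activity at all in this assay.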